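A few compounds are considered here, and "the series" means these few. Any claim that something is new, unique, unknown or untested is made for them only; others in the source may bear on it.

Working notes on the series. In a functional assay on A498 cells (Homo sapiens) for cytotoxicity (on this read-out lower numbers stand for stronger inhibition of growth and higher numbers for weaker inhibition of growth), compound 1 `CSc1ccc(C2=C(c3ccc(F)c(F)c3)C(=O)N3CCCC3C2)cc1` gives 100 nM. In this assay compound 2 `CSc1ccc(C2=C(c3ccc(F)c(C)c3)C(=O)N3CCCC3C2)cc1` gives 300 nM. In this assay compound 3 `CSc1ccc(C2=C(c3ccc(C)cc3)C(=O)N3CCCC3C2)cc1` gives 4000 nM, and it stands apart through the steps of a 40-fold higher number from compound 1 to compound 3 (1.60 log units; beyond the scatter) and a 13-fold higher number from compound 2 to compound 3 (1.12 log units; beyond the scatter). Its core differs from that of compound 2 by 4-methylphenyl in place of 4-fluoro-3-methylphenyl on a double-bonded ring carbon.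

Compound 4 `CSc1ccc(C2=C(c3ccc(F)cc3)C(=O)N3CCCC3C2)cc1` is not yet measured. It differs from compound 3 by fluoro in place of methyl on an aromatic carbon. The same kind of change, (fluoro in place of methyl on an aromatic carbon), gave the step of a 3.0-fold lower number from compound 2 to compound 1 (0.48 log units; beyond the scatter). The surroundings differ, though: there the fluoro sits ortho to a fluoro group and meta to a large group, whereas here it sits para to a large group, so this is the same kind of change, not the same. Going by the values given here, for compound 4 a step of a 3.1-fold lower number from compound 3 to compound 4 (0.49 log units; beyond the scatter) in this assay is expected, resting on a 3.0-fold lower number from compound 2 to compound 1 (0.48 log units; beyond the scatter) as the only precedent. Compound 4 is therefore estimated at 1300 nM, with a likely range from 400 nM to 4000 nM.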

Compound 4, concentration for 50% growth inhibition: 100 nM
The estimate for compound 4 lay 13-fold (1.11 log units) above the measured number; the measured number lies below the stated range.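

In this assay, fluoro in place of methyl lowers the number on both cores, but not by a size that carries from one to the other: the same change on two cores in this assay, a 3.0-fold lower number (0.48 log units; beyond the scatter) from compound 2 to compound 1 and a 40-fold lower number (1.60 log units; beyond the scatter) from compound 3 to compound 4, 13-fold (1.12 log units) apart, beyond the scatter of two such steps

The new pair gives a 40-fold lower number from compound 3 to compound 4 (1.60 log units; beyond the scatter), while hydrogen in place of methyl gives a 3.0-fold lower number from compound 2 to compound 4 (0.48 log units; beyond the scatter), and hydrogen in place of fluoro gives no change at the digits printed from compound 1 to compound 4 (within the scatter). Two pairs show a shared direction for this change, but they do not show why its size differs or how it would behave on a further core.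

Still open, on these data alone, is how a chloro, a methoxy or an amine in place of the fluoro of compound 4 would read in this assay.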